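The source may hold more compounds than are shown below. What is called first, only, known or untested is meant among the compounds shown, and "the series" means these compounds.

Measured compounds:
compound 1, `Cc1noc(NS(=O)(=O)c2cccc3c(NC(=O)C(C)C)cccc23)c1C`, 880 nM
compound 2, `Cc1noc(NS(=O)(=O)c2ccc(NC(=O)CN)cc2)c1C`, 6500 nM

Both compounds carry the same sulfonamide-bearing core, and both were tested in an assay on VSM-A10 cells for antagonist activity at Endothelin-1 receptor (Rattus norvegicus); a higher number here means a weaker inhibitor, a lower number a stronger inhibitor. Compound 1 gives 880 nM, and compound 2 gives 6500 nM. Compound 1 thus stands lowest of the two numbers, and its gap to compound 2 lies beyond the scatter of the method. The two compounds differ in more than one place, so no single change can be read from their values; only the gap itself is known.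

Compound 3, `Cc1noc(NS(=O)(=O)c2cccc3ccccc23)c1C`, has not yet been measured in this assay. It is obtained from compound 1 by one change: hydrogen in place of (isopropylcarbonyl)amino on an aromatic carbon. For the measured compounds named here, no measured pair here isolates this change, so the size of its step rests on expectation alone. Compound 1 gives 880 nM with the (isopropylcarbonyl)amino group in place, and its loss is expected to raise the number clearly beyond the scatter. The expected step is a 4.0-fold higher number from compound 1 to compound 3 (0.60 log units; beyond the scatter). Compound 3 is therefore estimated at 3500 nM, with a range from 1000 nM to 12000 nM.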

Compound 3, half-maximal inhibitory concentration: 20000 nM
For compound 3 the middle estimate is 5.7-fold (0.76 log units) below the measured one; the whole stated range lies below it.
By their numbers in this assay, from the lowest: compound 1; then compound 2; then compound 3.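

For the compounds shown here, compound 3 gives the first reading of this position on its own: with hydrogen in place of (isopropylcarbonyl)amino on the aromatic carbon, this assay shows a 23-fold higher number from compound 1 to compound 3 (1.36 log units; beyond the scatter). The earlier compounds shown here differed in more than one place and offered only a gap, whereas this pair ties a large change in the number to this single group on the core of compound 1. It shows that, on this core, inhibition depends strongly on the (isopropylcarbonyl)amino group, and that the core with hydrogen at this carbon is a clearly weaker inhibitor; no measured information bears on why the step has this size.

Going by these compounds alone, with only one group compared against hydrogen at this carbon, it remains open which part of the (isopropylcarbonyl)amino group carries the step, and whether a plain amine, a carboxylic acid or an amide with a longer chain would match compound 1, fall short of it or surpass it. On these data alone, it also remains open whether the same group would give a step of similar size at another aromatic carbon of the core.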